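Adding a second chloro to compound 2

This account rests on a few compounds, and the source may have more. Where it says the series, first, only, none or still open, it means among the compounds named here.

Measured so far:
Compound 1 `C=CC(=O)Nc1cccc(NC(=O)CSc2nc(Nc3cccc(F)c3)c3ccccc3n2)c1`: in a functional assay on MGC-803 cells (Homo sapiens) for inhibition, read by MTT assay, with a stated time of 72 h (on this read-out higher numbers stand for weaker inhibition and lower numbers for stronger inhibition), compound 1 gives 6250 nM
Compound 2 `C=CC(=O)Nc1cccc(NC(=O)CSc2nc(Nc3ccc(Cl)cc3)c3ccccc3n2)c1`: in this assay compound 2 gives 14300 nM

Going by the values given here, compound 2 stands highest of the two numbers; the only step in hand, a 2.3-fold higher number from compound 1 to compound 2 (0.36 log units; beyond the scatter), is modest though beyond the scatter. Compound 3 `C=CC(=O)Nc1cccc(NC(=O)CSc2nc(Nc3ccc(Cl)c(Cl)c3)c3ccccc3n2)c1` differs from compound 2 by chloro in place of hydrogen on an aromatic carbon. Among the compounds with values here, no measured step adds a halogen to an already substituted ring, so the step from compound 1 to compound 2 bears on it only loosely, and it was itself modest. In this assay compound 3 is therefore expected to sit near compound 2, with a step of a 1.6-fold lower number from compound 2 to compound 3 (0.20 log units; within the scatter) that may not exceed the scatter. The estimate for compound 3 is 9000 nM, within 3500 nM to 25000 nM.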

Compound 3, half-maximal inhibitory concentration: > 50000 nM
Compound 3: only a limit was reported; the forecaster's own chance of this, stated with the estimate: 5%; middle value at least 5.5-fold (0.74 log units) away from the limit.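

Adding a chloro ortho to the existing chloro group is the first change in the series to reach a limit: in this assay compound 3 gives > 50000 nM, which is a limit and not a number. The change makes inhibition weaker, with an at least 3.4-fold higher number from compound 2 to compound 3 (0.54 log units; beyond the scatter). Against the 3-fluorophenyl compound, the 3,4-dichlorophenyl group gives an at least 8.0-fold higher number from compound 1 to compound 3 (0.90 log units; beyond the scatter), and the true size of both steps stays unknown.

The compounds shown give no reason for this loss. Also open, going by these compounds, is whether a methoxy or an amine at the same position would weaken inhibition as the chloro does.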